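The source may hold more compounds than are shown below. What is called first, only, known or untested is meant among the compounds shown, and "the series" means these compounds.

Three close relatives of one shared core have been examined in an assay on isolated protein for inhibition of malate dehydrogenase, mitochondrial (Sus scrofa), with stated times of 45 min and 30 min; a lower number here means a stronger inhibitor, a higher number a weaker inhibitor. Compound 1 `Cc1ccc(S(=O)(=O)Nc2ccc(-c3nc4ccccc4o3)cc2)cc1` gives a result that is only a limit of the assay, > 63000 nM. Compound 2 `O=S(=O)(Nc1ccc(-c2nc3ccccc3o2)cc1)c1ccc(O)cc1` likewise reaches only the limit > 63000 nM. Compound 3 `COc1ccccc1S(=O)(=O)Nc1ccc(-c2nc3ccccc3o2)cc1` also stops at the limit, > 63000 nM. Because every result sits at the limit of > 63000 nM in this assay, at which 3 of the 3 values shown sit, compound 3 cannot be placed above or below its two companions; all three stand together at the edge of what this assay can report. The measured steps tell the same story: a step that the two limits leave unreadable from compound 1 to compound 2, a step that the two limits leave unreadable from compound 1 to compound 3 and a step that the two limits leave unreadable from compound 2 to compound 3 are each unreadable, both ends being limits rather than numbers. Compound 4 `O=S(=O)(Nc1ccc(-c2nc3ccccc3o2)cc1)c1ccc(F)cc1` is the next candidate, and the change from compound 3 is 4-fluorophenyl in place of 2-methoxyphenyl on a sulfonyl sulfur. None of the three measured steps carries a readable size that bears on this change, and each of them ends at the same limit. The expected size of the step is a step that the limit leaves unreadable from compound 3 to compound 4, that is, no movement beyond the scatter, with the result most likely reported again only as a limit. Compound 4 is therefore expected to give about 100000 nM in this assay, within a range from 30000 nM to 400000 nM.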

Compound 4, half-maximal inhibitory concentration: > 63000 nM
Compound 4: no number, only a limit; the forecaster's own chance of this, stated with the estimate: 85%; the middle value does not contradict the limit.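

In this assay compound 4 gives > 63000 nM, which is a limit of the assay and not a number. The steps joining compound 4 to compound 1, compound 2 and compound 3 therefore cannot be read: the limit of > 63000 nM in this assay, at which 4 of the 4 values shown sit. The compounds shown leave open whether any of these groups on the sulfonyl sulfur differs from the others in this assay.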